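Swapping methyl for fluoro on the phenoxy ring

The compounds below may be only part of what the source reports. "The series", "measured", "known", "first", "only" and "open" are said of these compounds alone.

Within the data shown here, compound 3 `Cc1ccc(Oc2ccc(/C=N/n3c(-c4ccccc4)nc4ccccc4c3=O)cc2)cc1` stands highest of the three numbers known in a physicochemical assay for lipophilicity, in phosphate buffer, measured as octanol-water partition (on this read-out higher numbers stand for higher lipophilicity and lower numbers for lower lipophilicity), and compound 3 gives 6.29. Among the measured compounds shown here, its nearest neighbour is compound 2 `O=c1c2ccccc2nc(-c2ccccc2)n1/N=C/c1ccc(Oc2ccccc2)cc1`, which gives 6.13 in this assay; the only single-point step seen so far runs a number 0.16 log units higher from compound 2 to compound 3 (within the scatter). Compound 1 `Cc1nc2ccccc2c(=O)n1/N=C/c1ccc(Oc2ccc(F)cc2)cc1` lies furthest away, giving 4.21 in this assay.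

Compound 4 `O=c1c2ccccc2nc(-c2ccccc2)n1/N=C/c1ccc(Oc2ccc(F)cc2)cc1` differs from compound 3 by fluoro in place of methyl on an aromatic carbon. For the measured compounds named here, no measured step covers this exact exchange. Going by the values given here, the one step available, methyl in place of hydrogen, was small, and compound 1 carries the same fluoro-bearing ring on a different core, so its value shows only that the two ends of that pairing sit far apart. Fluoro is expected to give a modest drop relative to methyl, but not a large one.

For compound 4 the expected step is a number 0.29 log units lower from compound 3 to compound 4 (within the scatter), and in this assay compound 4 is estimated at 6, with a range from 5.6 to 6.5.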

Compound 4, partition coefficient: 6.21
Compound 4: the middle estimate sits 0.21 log units below what was measured; the range from low to high includes it.
By their numbers in this assay, from the lowest: compound 1; then compounds 2, 4 and 3 (each within the scatter of the next).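

With compound 4, the ring carbon para to a large group has now carried hydrogen, methyl and fluoro, and this assay does not tell these three apart: the reading goes a number 0.08 log units lower from compound 3 to compound 4 (within the scatter) and a number 0.08 log units higher from compound 2 to compound 4 (within the scatter), so swapping one small group for another at this place leaves the number within its usual spread. The large move lies elsewhere, on the core, where a methyl gives way to a phenyl, a change that gives a number 2.00 log units higher from compound 1 to compound 4 (beyond the scatter) and far outweighs anything seen on the outer ring. Nothing measured here explains either result.

On these data alone, it remains open whether an amine, a carboxylic acid or a longer chain at this same place would also leave the number where it is. It is also open whether hydrogen and methyl would match fluoro on the core of compound 1, where only fluoro is shown.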